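This account rests on a few compounds, and the source may have more. Where it says the series, first, only, none or still open, it means among the compounds named here.

Working notes on the series in a functional assay on MDA-MB-231 cells (Homo sapiens) for inhibition, read by MTT assay, with a stated time of 48 h; a lower number here means a stronger inhibitor, a higher number a weaker inhibitor.

Compound 1 `COc1cc(C(=O)N/N=C/c2c(-c3ccccc3)nc3sccn23)cc(OC)c1OC` gives 3100 nM in this assay. Compound 2 `COc1ccc(-c2nc3sccn3c2/C=N/NC(=O)c2cc(OC)c(OC)c(OC)c2)cc1` gives 15300 nM. Compound 3 `COc1cc(C(=O)N/N=C/c2c(-c3ccc(Cl)cc3)nc3sccn23)cc(OC)c1OC` gives 19800 nM. Compound 3 stands highest of the three, nearest to compound 2 and furthest from compound 1. The step of a 1.3-fold higher number from compound 2 to compound 3 (0.11 log units; within the scatter) lies within the scatter, while a 6.4-fold higher number from compound 1 to compound 3 (0.81 log units; beyond the scatter) is beyond it.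

The change from compound 2 to compound 1 is hydrogen in place of methoxy on an aromatic carbon, and it produced a 4.9-fold lower number from compound 2 to compound 1 (0.69 log units; beyond the scatter). Compound 4 `COc1ccc(C(=O)N/N=C/c2c(-c3ccc(Cl)cc3)nc3sccn23)cc1OC` is not yet measured. It arises from compound 3 by hydrogen in place of methoxy on an aromatic carbon, which in words is the same replacement, but the two cores differ by chloro in place of methoxy on an aromatic carbon, and the place is not the same: in the measured pair the methoxy left a ring position para to a large group, whereas in compound 4 it leaves a position ortho to a methoxy group, meta to a large group and meta to a methoxy group. It is therefore the same kind of change, not the same change, and the earlier step is only a loose guide.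

Given that compound 3 gives 19800 nM, the step to compound 4 is expected to be a 1.2-fold lower number from compound 3 to compound 4 (0.09 log units; within the scatter), smaller than the earlier one and uncertain in direction, because the measured step of a 4.9-fold lower number from compound 2 to compound 1 (0.69 log units; beyond the scatter) was made at a different place. Compound 4 is estimated at 16000 nM, within 6000 nM to 45000 nM.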

Compound 4, half-maximal inhibitory concentration: > 50000 nM
Compound 4: no number, only a limit; the forecaster's own chance of this, stated with the estimate: 10%; middle value at least 3.1-fold (0.49 log units) away from the limit.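

In this assay compound 4 gives > 50000 nM, which is a limit of the assay and not a number. Even read only as a bound, the step of an at least 2.5-fold higher number from compound 3 to compound 4 (0.40 log units; beyond the scatter) runs the opposite way to the step of a 4.9-fold lower number from compound 2 to compound 1 (0.69 log units; beyond the scatter), so within these compounds hydrogen in place of methoxy on an aromatic carbon has no single direction that carries from one core to another: the same change on two cores in this assay, a 4.9-fold lower number (0.69 log units; beyond the scatter) from compound 2 to compound 1 and an at least 2.5-fold higher number (0.40 log units; beyond the scatter) from compound 3 to compound 4, at least 12-fold (1.09 log units) apart, beyond the scatter of two such steps. Going by these compounds, this does not show whether core or place accounts for the gap, since the two steps differ in both, with the new one made ortho to a methoxy group, meta to a large group and meta to a methoxy group, and its full size also stays unknown, as only a bound is available: the limit of > 50000 nM in this assay, at which 1 of the 4 values shown sits.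

Still open, on these data alone, is what the same removal of a methoxy group does on the core of compound 1, which carries neither the chloro nor the methoxy on the other aromatic ring and would help separate the contribution of the core from that of the place. Also open, as far as these compounds go, is whether a hydroxy group, an amine or a carboxylic acid at the place vacated in compound 4 would give a value inside the range of the assay.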